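Swapping the para substituent on a shared core: expected solubility

The source may report more compounds than this note shows. Statements on the series, on what has been measured and on what is new or still open speak of the compounds shown alone.

Measured so far:
compound 1, `Cc1cc(Nc2ccc(S(F)(F)(F)(F)F)cc2)n2nc(C3CC3)nc2n1` — 16000 nM
compound 2, `Cc1cc(Nc2ccc(C(F)(F)F)cc2)n2nc(C3CC3)nc2n1` — 38000 nM
compound 3, `CSc1nc2nc(C)cc(Nc3ccc(S(F)(F)(F)(F)F)cc3)n2n1` — 7800 nM

In a physicochemical assay for solubility, at pH 6.5 (a higher number here means a more soluble compound, a lower number a less soluble compound), compound 1 gives 16000 nM. Compound 2 differs from it by a group of 4 heavy atoms (1 carbon, 3 fluorine; no ring) in place of a group of 6 heavy atoms (5 fluorine, 1 sulfur; no ring), on an aromatic carbon, and this change made a 2.4-fold higher number from compound 1 to compound 2 (0.38 log units; beyond the scatter). Compound 3 carries a different core, differing from compound 1 by methylsulfanyl in place of cyclopropyl on an aromatic carbon, and in this assay compound 3 gives 7800 nM, the lowest of the three.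

Compound 4, `CSc1nc2nc(C)cc(Nc3ccc(C(F)(F)F)cc3)n2n1`, has not yet been measured. It differs from compound 3 by a group of 4 heavy atoms (1 carbon, 3 fluorine; no ring) in place of a group of 6 heavy atoms (5 fluorine, 1 sulfur; no ring), on an aromatic carbon. The two place descriptions read the same word for word, so this is the same change already seen between compound 1 and compound 2, now made on the core of compound 3.

Because a 2.4-fold higher number from compound 1 to compound 2 (0.38 log units; beyond the scatter), a step of similar size is expected from compound 3 to compound 4, namely a 2.3-fold higher number from compound 3 to compound 4 (0.36 log units; beyond the scatter). This rests on a single earlier example, so the range is kept wide. Compound 4 is estimated at 18000 nM, expected to fall between 9000 nM and 40000 nM.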

Compound 4, solubility: 19000 nM
Estimate against measurement, compound 4: 1.1-fold (0.02 log units) below; measured number inside the range.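

In this assay, putting trifluoromethyl in place of the group of 6 heavy atoms (5 fluorine, 1 sulfur) gave a 2.4-fold higher number from compound 3 to compound 4 (0.39 log units; beyond the scatter) on the core of compound 3, a step close in size to a 2.4-fold higher number from compound 1 to compound 2 (0.38 log units; beyond the scatter) on the core of compound 1. Read the other way, methylsulfanyl in place of cyclopropyl gives a 2.0-fold lower number from compound 2 to compound 4 (0.30 log units; within the scatter) with trifluoromethyl on the ring, a step that lies within the scatter. The match shows that this one change carried over between these two cores, but it rests on just two pairs of compounds, does not show that it would carry to any other core, and comes with no measured explanation of why the two steps agree.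

The compounds shown leave open whether another group at the same place, such as a nitrile or an amine, would give a step that also repeats across both cores. They also leave open whether the step would hold on a core carrying a longer chain or a carboxylic acid in place of cyclopropyl or methylsulfanyl.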